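This account rests on a few compounds, and the source may have more. Where it says the series, first, only, none or still open, it means among the compounds named here.

Compound 1, `COC(=O)c1cc(-c2cccc(NC(=O)c3ccc(/C=C/C(=O)c4ccccc4OC)cc3)c2)on1`, gives in an ADME assay on Vero cells (Chlorocebus sabaeus) for cytotoxicity, read by MTT assay, with a stated time of 72 h (on this read-out lower numbers stand for higher toxicity in this test and higher numbers for lower toxicity in this test), a limit of > 40 ug/mL. Compound 2, `COC(=O)c1cc(-c2cccc(NC(=O)c3ccc(/C=C/C(=O)c4ccc(F)cc4)cc3)c2)on1`, gives in this assay a limit of > 20 ug/mL.

Among the measured compounds shown here, compound 2 therefore stands only at a limit, and the one further value shown is a limit too. For the measured compounds named here, the sole measured step, a step that the two limits leave unreadable from compound 1 to compound 2, cannot be read because its two ends sit at the limit of > 40 ug/mL in this assay, at which 1 of the 2 values shown sits, and (the limit of > 20 ug/mL in this assay, at which 1 of the 2 values shown sits). The step to compound 3, `CCOc1ccc(C(=O)/C=C/c2ccc(C(=O)Nc3cccc(-c4cc(C(=O)OC)no4)c3)cc2)cc1`, changes (ethoxy in place of fluoro on an aromatic carbon), the (4-fluorophenyl)carbonyl becoming a (4-ethoxyphenyl)carbonyl, para to a large group. Going by the values given here, no measured step bears on this change in a readable way, so no step beyond the scatter is expected in this assay; compound 3 is expected to stay near the limits seen, with an expected step that the limit leaves unreadable from compound 2 to compound 3. Compound 3 is thus estimated at 40 ug/mL, within 20 ug/mL to 80 ug/mL.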

Compound 3, half-maximal cytotoxic concentration: > 40 ug/mL
Compound 3 ended at the assay's limit; the forecaster's own chance of this, stated with the estimate: 60%; the middle value sits exactly at the limit.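

In this assay, among the compounds shown here, compound 1, compound 2 and compound 3 all give limits of the assay and not numbers, so no step among them can be read. The compounds shown leave open where any true value lies, and whether changing the phenyl group on the carbonyl alters cytotoxicity at all.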